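This account rests on a few compounds, and the source may have more. Where it says the series, first, only, none or still open, it means among the compounds named here.

Compound 1 `Cc1ccc(S(=O)(=O)N[C@H]2CC[C@H](O)[C@@H]2C/C=C\CCC(=O)O)cc1`, in a functional assay (plasma) for inhibition, with Homo sapiens as the target (on this read-out higher numbers stand for weaker inhibition and lower numbers for stronger inhibition), compound 1 gives 2500 nM.
Compound 2 `Cc1ccc(S(=O)(=O)N[C@H]2CC/C(=N\OCC3CCCCC3)[C@@H]2C/C=C\CCCC(=O)O)cc1`, in this assay compound 2 gives 600 nM.
Compound 3 `O=C(O)CC/C=C\C[C@@H]1[C@@H](NS(=O)(=O)c2ccc(F)cc2)CC[C@@H]1O`, in this assay compound 3 gives 1600 nM.

Compound 3 is made from compound 1 by one change, (fluoro in place of methyl on an aromatic carbon), and the measured step is a 1.6-fold lower number from compound 1 to compound 3 (0.19 log units; within the scatter). Compound 2 carries a different core; the difference between the two cores is not broken down here. Among the three measured compounds, compound 2 holds the lowest number, and its steps to compound 3 and to compound 1 both lie beyond the scatter.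

Compound 4 `O=C(O)CCC/C=C\C[C@H]1/C(=N/OCC2CCCCC2)CC[C@@H]1NS(=O)(=O)c1ccc(F)cc1` has not yet been measured in this assay. It stands to compound 2 as compound 3 stands to compound 1: the change is fluoro in place of methyl on an aromatic carbon, at the same place in the same words, so it is the same change, seen now on the core of compound 2. Among the compounds with values here, the one earlier instance of this change moved the number only within the scatter. On that basis the step is estimated at a 1.3-fold lower number from compound 2 to compound 4 (0.12 log units; within the scatter), a size expected to resemble the earlier one, because that earlier step was a 1.6-fold lower number from compound 1 to compound 3 (0.19 log units; within the scatter). Compound 4 is therefore expected to give 450 nM in this assay, most likely between 200 nM and 1000 nM.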

Compound 4, half-maximal inhibitory concentration: 1800 nM
Compound 4: the middle estimate sits 4.0-fold (0.60 log units) below what was measured; measured number outside the range, above it.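

On the core of compound 2, fluoro in place of methyl gives a 3.0-fold higher number from compound 2 to compound 4 (0.48 log units; beyond the scatter) in this assay. The same change therefore did not carry over from one core to the other with the same size or direction, and the two steps differ: the same change on two cores in this assay, a 1.6-fold lower number (0.19 log units; within the scatter) from compound 1 to compound 3 and a 3.0-fold higher number (0.48 log units; beyond the scatter) from compound 2 to compound 4, 4.7-fold (0.67 log units) apart, beyond the scatter of two such steps This comparison rests on a single pair for each core, so it shows that the step seen on one core could not be transferred to the other here, but it does not show which feature of the two cores goes with the difference, or how the change would read on any further core.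

The compounds shown leave open how a chloro or a methoxy group on the same aromatic carbon would read on each of the two cores. They also leave open whether a plain phenyl group, with hydrogen in place of methyl or fluoro, would show the two cores parting in the same way.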